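The source may hold more compounds than are shown below. What is called first, only, known or untested is meant among the compounds shown, and "the series" means these compounds.

Measured compounds in a functional assay on the whole organism (Tail, strain ICR) with Mus musculus as the target, in the tail flick test, with a stated time of 150 min, at a dose of 25 umol/kg by the oral route; on this read-out lower numbers stand for a weaker effect and higher numbers for a stronger effect at the one dose given:
- compound 1, `N=C(N)NCCC[C@H](NC(=O)CN(c1nc(Cl)nc2[nH]cnc12)C1CC1)C(=O)O`, gives 7.19%
- compound 2, `O=C(OCc1ccccc1)[C@@H]1CCCN1C(=O)CN(c1nc(Cl)nc2[nH]cnc12)C1CC1`, gives 31.1%
- compound 3, `N=C(N)NCCC[C@H](NC(=O)CN(c1nc(Cl)nc2[nH]cnc12)C1CC1)C(=O)OCc1ccccc1`, gives 6.12%

Compound 1 stands second highest of the three numbers in this assay. Its nearest neighbour is compound 3, and that step, a number 1.1 percentage points lower from compound 1 to compound 3 (within the scatter), lies within the scatter. For the measured compounds named here, its furthest neighbour is compound 2, whose value is higher by a margin beyond the scatter; no single-place step links compound 1 and compound 2, so their two values are all that can be said of that pair.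

Compound 4, `C[C@@H](O)[C@H](NC(=O)CN(c1nc(Cl)nc2[nH]cnc12)C1CC1)C(=O)O`, is not yet measured in this assay. It differs from compound 1 by a group of 3 heavy atoms (2 carbon, 1 oxygen; no ring) in place of a group of 7 heavy atoms (4 carbon, 3 nitrogen; no ring), on a saturated chain carbon bound to an amide-type nitrogen and a carbonyl carbon. Going by the values given here, none of the measured steps touches this place: the only step on record, from compound 1 to compound 3, alters the oxygen of the carbonyl group and stays within the scatter, so it gives no direct guide. The gap between compound 1 and compound 2 shows that a change in the amino-acid part can move the number beyond the scatter, but in which direction for compound 4 is not settled.

The expected step is a number 4.8 percentage points higher from compound 1 to compound 4 (within the scatter). Compound 4 is estimated at 12%, in a range from 3% to 30%.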

Compound 4, a percentage reported as activity, at one dose (the size of the read-out at that dose, not a potency): 24%
Compound 4: middle estimate off by 12 percentage points, on the low side, and the stated range covers the measured number.
By their numbers in this assay, from the lowest: compounds 3 and 1 (each within the scatter of the next); then compounds 4 and 2 (each within the scatter of the next).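

In this assay, the saturated chain carbon bound to an amide-type nitrogen and a carbonyl carbon proves sensitive to its substituent: 1-hydroxyethyl in place of the group of 7 heavy atoms gives a number 16.8 percentage points higher from compound 1 to compound 4 (beyond the scatter). For the compounds shown here, this is the first single-place step to pass the scatter, whereas the earlier step, on the oxygen next to a carbonyl group, stayed within it, and it fixes the direction for this one change only. No measurement bearing on the origin of this step is at hand.

From the compounds shown here alone, what an ethyl or a hydroxymethyl group would give on this carbon remains open, so the share of the hydroxyl in the step cannot be told. Going by these compounds, it is also open whether a benzyl ester of compound 4 would stay as close to compound 4 as compound 3 does to compound 1.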